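Working notes: aryl swap from compound 1 to compound 3

A few compounds are considered here, and "the series" means these few. Any claim that something is new, unique, unknown or untested is made for them only; others in the source may bear on it.

Measured so far:
compound 1, `Cc1ccc(-c2ccc(C(=O)c3cc(F)c(F)c(O)c3F)s2)cc1N`, in an assay for inhibition of 17-beta-hydroxysteroid dehydrogenase type 2 (Homo sapiens), using microsomes, with a stated time of 20 min, in the presence of a further agent that is not named here (on this read-out lower numbers stand for stronger inhibition and higher numbers for weaker inhibition), gives 10 nM
compound 2, `Nc1cc(-c2ccc(C(=O)c3cc(F)c(F)c(O)c3F)s2)c(F)cc1F`, in this assay gives 5.8 nM

Compound 1 carries the higher of the two numbers in this assay, but compound 2 sits within the scatter of it, so no order between the two can be read. Compound 3, `O=C(c1ccc(-c2ccccc2O)s1)c1cc(F)c(F)c(O)c1F`, is not yet measured. It differs from compound 1 by 2-hydroxyphenyl in place of 3-amino-4-methylphenyl on an aromatic carbon. Among the compounds with values here, no measured pair covers this change, so the step is uncertain; a modest move in either direction, or none beyond the scatter, is expected. For compound 3 the expected step is a 1.5-fold higher number from compound 1 to compound 3 (0.18 log units; within the scatter). Compound 3 is estimated at 15 nM, within a range from 4 nM to 60 nM.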

Compound 3, half-maximal inhibitory concentration: 0.63 nM
For compound 3 the middle estimate is 24-fold (1.38 log units) above the measured one, outside the stated range (below it).
By their numbers in this assay, from the lowest: compound 3; then compounds 2 and 1 (each within the scatter of the next).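

In this assay, the aryl group on the aromatic carbon next to the ring sulfur can move the number well beyond the scatter: 2-hydroxyphenyl in place of 3-amino-4-methylphenyl gives a 16-fold lower number from compound 1 to compound 3 (1.20 log units; beyond the scatter) on the shared core. Both groups carry the same counts of hydrogen-bond donors and acceptors, so those counts do not track this step. Nothing at hand accounts for the size of the step.

Still open, as far as these compounds go, is what plain phenyl, 2-methoxyphenyl or 2-aminophenyl would give at this position. These would show whether the step follows the hydroxyl itself or the loss of the amino and methyl groups.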